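The compounds below may be only part of what the source reports. "The series", "measured", "known", "first", "only" and "open" are said of these compounds alone.

Measured compounds:
compound 1, `Oc1ccccc1-c1cc(-c2ccccn2)cc(-c2ccccc2O)n1`, > 50000 nM in a functional assay on HeLa cells (Homo sapiens) for cytotoxicity, read by CCK-8 assay; on this read-out lower numbers stand for stronger inhibition and higher numbers for weaker inhibition
compound 2, `Oc1cccc(-c2cc(-c3ccccn3)cc(-c3ccccc3O)n2)c1`, 2020 nM in this assay
compound 3, `Oc1cccc(-c2cc(-c3cccnc3)cc(-c3ccccc3O)n2)c1`, 7530 nM in this assay

The value of compound 1 is a limit of this assay and not a number (the limit of > 50000 nM in this assay, at which 1 of the 3 values shown sits). From compound 1 to compound 2 the change is 3-hydroxyphenyl in place of 2-hydroxyphenyl on an aromatic carbon, and it gave an at least 24-fold lower number from compound 1 to compound 2 (1.39 log units; beyond the scatter). From compound 2 to compound 3 the change gave a 3.7-fold higher number from compound 2 to compound 3 (0.57 log units; beyond the scatter). The difference between the cores of compound 1 and compound 3 is not broken down here.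

Compound 4, `Oc1cccc(-c2cc(-c3cccnc3)cc(-c3cccc(O)c3)n2)c1`, is not yet measured. It differs from compound 3 by 3-hydroxyphenyl in place of 2-hydroxyphenyl on an aromatic carbon. Within the data shown here, this is the same kind of change as the one from compound 1 to compound 2, though the surroundings differ: here the place is meta to a 3-hydroxyphenyl group and meta to a pyridin-3-yl group, whereas earlier it was meta to a 2-hydroxyphenyl group and meta to a pyridin-2-yl group.

Resting on compound 1 to compound 2 giving an at least 24-fold lower number from compound 1 to compound 2 (1.39 log units; beyond the scatter), compound 4 is expected to show an 11-fold lower number from compound 3 to compound 4 (1.03 log units; beyond the scatter), a large step in the same direction. Compound 4 is therefore estimated at 700 nM in this assay, likely between 150 nM and 3000 nM.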

Compound 4, half-maximal inhibitory concentration: > 50000 nM
Compound 4: only a limit was reported; the forecaster's own chance of this, stated with the estimate: 5%; middle value at least 71-fold (1.85 log units) from the limit.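

The same swap did not carry over to the new core: in this assay 3-hydroxyphenyl in place of 2-hydroxyphenyl gave an at least 6.6-fold higher number from compound 3 to compound 4 (0.82 log units; beyond the scatter), the opposite direction to the earlier step. Compound 4 gives > 50000 nM, which is a limit of the assay and not a number. The effect of this change therefore depends on the core it is made on, but the two cores differ in both the pyridine group and the second hydroxyphenyl group, so this comparison does not show which of them reverses the result, and one pair of steps gives no rule for the whole series: the same change on two cores in this assay, an at least 24-fold lower number (1.39 log units; beyond the scatter) from compound 1 to compound 2 and an at least 6.6-fold higher number (0.82 log units; beyond the scatter) from compound 3 to compound 4, at least 160-fold (2.21 log units) apart, beyond the scatter of two such steps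

The compounds shown leave open how a pyridin-2-yl compound with two 3-hydroxyphenyl groups would behave, and such a compound would help to separate those two differences. Also open, from the compounds shown here alone, is what happens when a pyridin-4-yl group replaces the pyridine groups seen here, or when a methoxy group or an amine replaces the hydroxyl groups.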